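This account rests on a few compounds, and the source may have more. Where it says the series, first, only, none or still open, it means among the compounds named here.

Measured so far in an ADME assay on microsomes from liver (Canis lupus familiaris) for metabolic stability; a higher number here means that the compound lasts longer, a lower number that the compound disappears faster:

- compound 1 `Nc1nc(NCCNc2ncc(-c3ncc[nH]3)c(-c3ccc(C(F)(F)F)cc3)n2)ccc1[N+](=O)[O-]` gives > 0.5 h
- compound 2 `Nc1nc(NCCNc2ncc(-c3ncc[nH]3)c(-c3cc(F)ccc3F)n2)ccc1[N+](=O)[O-]` gives > 0.5 h
- compound 3 `Nc1nc(NCCNc2ncc(-c3ncc[nH]3)c(-c3cc(F)c(F)cc3F)n2)ccc1[N+](=O)[O-]` gives > 0.5 h

Each of these entries is a limit of the assay and not a number. Compound 3 therefore stands only at the limit > 0.5 h and has no readable half-life. Among the measured compounds shown here, the series so far shows the limit of > 0.5 h in this assay, at which 3 of the 3 values shown sit, and no compound can be placed ahead of another.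

The change to compound 4 `Nc1nc(NCCNc2ncc(-c3ncc[nH]3)c(-c3cc(F)ccc3Cl)n2)ccc1[N+](=O)[O-]` is 2-chloro-5-fluorophenyl in place of 2,4,5-trifluorophenyl on an aromatic carbon with 2-chloro-5-fluorophenyl in place of 2,4,5-trifluorophenyl, on an aromatic carbon ortho to a 1H-imidazol-2-yl group.

For the measured compounds named here, three measured steps bear on this change. Going by the values given here, the first is a step that the two limits leave unreadable from compound 2 to compound 3 for fluoro in place of hydrogen, and the other two are the aryl exchanges a step that the two limits leave unreadable from compound 1 to compound 2 and a step that the two limits leave unreadable from compound 1 to compound 3 in the same place. None of them has a readable size, so they give no direction. All three aryl groups do share the same limit, which is the only basis for expecting little movement in this assay here.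

The expected change is a step that the limit leaves unreadable from compound 3 to compound 4 and no step beyond the scatter is expected in either direction. Another report as a limit is the likeliest outcome. For compound 4 the estimate is 0.8 h with an expected range from 0.4 h to 2 h in this case.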

Compound 4, half-life: > 0.5 h
Compound 4: a limit, no number; the forecaster's own chance of this, stated with the estimate: 75%; the middle value is on the limit's open side.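

Compound 4 is again reported as a limit and not a number in this assay, so its steps from compound 1, compound 2 and compound 3 cannot be read, and the series stays at a single reading: the limit of > 0.5 h in this assay, at which 4 of the 4 values shown sit.

The compounds shown leave open whether their half-lives differ at all, and in what order they would fall.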